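Chain length at the ether and cytotoxicity toward prostate cancer cells

The compounds below may be only part of what the source reports. "The series", "measured", "known", "first", "only" and "open" are said of these compounds alone.

Measured so far:
- compound 1, `CCCCOCNc1n[n+]([O-])c2ccccc2[n+]1[O-]`: 6010 nM
- compound 2, `CCOCNc1n[n+]([O-])c2ccccc2[n+]1[O-]`: 7400 nM

Both compounds share one core and differ only in the chain hanging from the ether oxygen. In a functional assay on PC-3 cells (Homo sapiens) for cytotoxicity, read by MTT assay, with a stated time of 72 h (a lower number here means a stronger inhibitor, a higher number a weaker inhibitor), compound 2 gives the higher of the two numbers, but its nearest neighbour is compound 1, and the step of a 1.2-fold higher number from compound 1 to compound 2 (0.09 log units; within the scatter) lies within the scatter, so the two cannot be told apart.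

Compound 3, `CC(C)CCOCNc1n[n+]([O-])c2ccccc2[n+]1[O-]`, has not yet been measured. It differs from compound 2 by isopropyl in place of hydrogen on a saturated chain carbon, two bonds along the chain from an oxygen on a saturated carbon. Among the compounds with values here, the only measured step that bears on this is the same kind of change at the same place, ethyl against hydrogen, which was a 1.2-fold higher number from compound 1 to compound 2 (0.09 log units; within the scatter). Growing the chain in the other direction is therefore expected to move this assay little, if at all, beyond the scatter: the expected step is a 1.2-fold lower number from compound 2 to compound 3 (0.09 log units; within the scatter). Compound 3 is accordingly estimated at 6000 nM, with a likely range from 3000 nM to 13000 nM.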

Compound 3, half-maximal inhibitory concentration: 7520 nM
The estimate for compound 3 lay 1.3-fold (0.10 log units) below the measured number; the measured number falls inside the stated range.
By their numbers in this assay, from the lowest: compounds 1, 2 and 3 (each within the scatter of the next).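

Isopropyl in place of hydrogen on this saturated chain carbon, an entering group of 3 heavy atoms, gives a 1.0-fold higher number from compound 2 to compound 3 (0.01 log units; within the scatter) in this assay, so this position has now taken both ethyl and isopropyl without a step beyond the scatter. Methyl in place of hydrogen on a saturated chain carbon bound to two saturated chain carbons gives a 1.3-fold higher number from compound 1 to compound 3 (0.10 log units; within the scatter) and likewise leaves the two compounds impossible to tell apart. Nothing available explains why these chain differences leave the readings so close.

Going by these compounds, all three chains contain only saturated carbon beyond the ether oxygen, so the effect of an amine, a carboxylic acid or a phenyl ring at this position remains open. On these data alone, a much longer chain also remains untested here, as do changes to the shared core.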